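The source may report more compounds than this note shows. Statements on the series, on what has been measured and on what is new or still open speak of the compounds shown alone.

Working notes on the series, read in a functional assay on DU-145 cells (Homo sapiens) for inhibition, read by MTT assay, with a stated time of 72 h; on this read-out higher numbers stand for weaker inhibition and lower numbers for stronger inhibition: compound 1 (`Cc1ccc(N2CCN(C3=CC(=O)c4ccccc4C3=O)CC2)cc1`) gives 8200 nM, compound 2 (`O=C1C=C(N2CCN(c3ccccc3)CC2)C(=O)c2ccccc21`) gives 9900 nM and compound 3 (`COc1cccc(N2CCN(C3=CC(=O)c4ccccc4C3=O)CC2)c1`) gives 15000 nM. These three numbers lie within the scatter of one another, so compound 3 has no separate standing in the set.

Compound 4 (`O=C1C=C(N2CCN(c3ccc(F)c(Cl)c3)CC2)C(=O)c2ccccc21`) differs from compound 3 in one place: 3-chloro-4-fluorophenyl in place of 3-methoxyphenyl on an amine nitrogen in a ring. In words, 3-chloro-4-fluorophenyl stands in place of 3-methoxyphenyl on an amine nitrogen in a ring.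

The measured steps that bear on this change are all at the same place: a 1.2-fold higher number from compound 1 to compound 2 (0.08 log units; within the scatter), a 1.5-fold higher number from compound 2 to compound 3 (0.18 log units; within the scatter) and a 1.8-fold higher number from compound 1 to compound 3 (0.26 log units; within the scatter). All three stay within the scatter, but none brings in chlorine or fluorine, so the evidence is indirect. On these steps, no change beyond the scatter is expected in this assay.

The expected step is a 1.7-fold lower number from compound 3 to compound 4 (0.22 log units; within the scatter). Compound 4 is estimated at 9000 nM, with an expected range of 3500 nM to 20000 nM.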

Compound 4, half-maximal inhibitory concentration: 32200 nM
Compound 4: middle estimate off by 3.6-fold (0.55 log units), on the low side; measured number outside the range, above it.
By their numbers in this assay, from the lowest: compounds 1, 2 and 3 (each within the scatter of the next); then compound 4.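

In this assay, among the compounds shown here, 3-chloro-4-fluorophenyl is the first group on the amine nitrogen in the ring to give a change beyond the scatter, with a 2.1-fold higher number from compound 3 to compound 4 (0.33 log units; beyond the scatter), a 3.3-fold higher number from compound 2 to compound 4 (0.51 log units; beyond the scatter) and a 3.9-fold higher number from compound 1 to compound 4 (0.59 log units; beyond the scatter), each a modest step. The position therefore tolerates phenyl, 4-methylphenyl and 3-methoxyphenyl without a readable difference, yet it is not indifferent to every aryl group, and compound 4 gives the weakest inhibition of the four. No measurement available here accounts for this step.

The compounds shown do not separate the contribution of chlorine from that of fluorine, which leaves open how 3-chlorophenyl or 4-fluorophenyl alone would read. Also open, going by these compounds, is how an aminomethyl or carboxylic acid group on the phenyl ring would read at this position.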